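Swapping Bromo for Methyl on the Aryl Group

This account rests on a few compounds, and the source may have more. Where it says the series, first, only, none or still open, it means among the compounds named here.

Of the compounds shown here, three that share one core have been measured in a functional assay on the whole organism for inhibition, with Rattus norvegicus as the target; on this read-out lower numbers stand for an effect already at smaller amounts and higher numbers for an effect only at larger amounts of compound. Compound 1 `CC1CCCc2ncc(C(=O)O)c(=O)n21`, the bare core, gives 240 umol/kg in this assay. Compound 2 `CC1CC/C(=N\Nc2cccc(Cl)c2)c2ncc(C(=O)O)c(=O)n21` adds a large substituent to that core and gives 0.6 umol/kg. Compound 3 `CC1CC/C(=N\Nc2cccc(Br)c2)c2ncc(C(=O)O)c(=O)n21` differs from compound 2 only by bromo in place of chloro; in this assay compound 3 gives 0.4 umol/kg. Compound 3 and compound 2 therefore sit together, separated by a 1.5-fold lower number from compound 2 to compound 3 (0.18 log units; within the scatter), while both stand far from compound 1, whose number is beyond the scatter away.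

Compound 4 `Cc1cccc(N/N=C2\CCC(C)n3c2ncc(C(=O)O)c3=O)c1` is the next member: methyl in place of bromo on an aromatic carbon. Going by the values given here, no measured step exchanges a halogen for a carbon group, so direct guidance is missing. Among the compounds with values here, the only step that bears on it, a 1.5-fold lower number from compound 2 to compound 3 (0.18 log units; within the scatter), exchanged one halogen for another and stayed within the scatter, which shows that this corner of the molecule has so far tolerated a change. A methyl is a different kind of substituent, so a small rise in the number cannot be excluded, but nothing measured demands one. Compound 4 is therefore expected to give about 0.7 umol/kg in this assay, with a likely range from 0.25 umol/kg to 2 umol/kg. That estimate corresponds to an expected step of a 1.8-fold higher number from compound 3 to compound 4 (0.24 log units; within the scatter), close to the edge of the scatter.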

Compound 4, dose for 50% inhibition: 0.4 umol/kg
Beside the measured number, compound 4's estimate is 1.8-fold (0.24 log units) above it; the measured number falls inside the stated range.
By their numbers in this assay, from the lowest: compounds 3, 4 and 2 (each within the scatter of the next); then compound 1.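

Until now this position had only seen one halogen exchanged for another; with a carbon group in place of a halogen, this assay shows no change at the digits printed from compound 3 to compound 4 (within the scatter), and for methyl in place of chloro it shows a 1.5-fold lower number from compound 2 to compound 4 (0.18 log units; within the scatter). Among these three compounds, then, the aryl group carries a chloro, a bromo or a methyl on this aromatic carbon with no step that leaves the scatter, so a halogen is not needed here for the number to stay where it is. Nothing available explains why these three substituents read alike.

The compounds shown leave open how far this tolerance reaches, for instance whether a group of another kind, such as an amine, a carboxylic acid, a methoxy or a longer chain like propyl, would keep the number in the same place on this aromatic carbon. They also leave open whether a methyl on a different carbon of the same ring, or a second substituent added to that ring, would read the same way.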